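Chloro to methoxy on an aromatic carbon: an expected step

A few compounds are considered here, and "the series" means these few. Any claim that something is new, unique, unknown or untested is made for them only; others in the source may bear on it.

compound 1 `COc1cc(/C=C/C(=O)c2cccc(-n3cc(-c4ccc(Cl)cc4)[nH]c3=O)c2)ccc1O`: 2640 nM
compound 2 `COc1cc(/C=C/C(=O)c2cccc(-n3cc(-c4ccccc4)[nH]c3=O)c2)cc(OC)c1OC`: 1750 nM
compound 3 `COc1ccc(-c2cn(-c3cccc(C(=O)/C=C/c4cc(OC)c(OC)c(OC)c4)c3)c(=O)[nH]2)cc1`: 3050 nM

In a functional assay on CAKI-1 cells (Homo sapiens) for inhibition (a higher number here means a weaker inhibitor of growth, a lower number a stronger inhibitor of growth), compound 1 gives 2640 nM, the second highest of the three numbers, within the scatter of both compound 3 and compound 2. Compound 4 `COc1ccc(-c2cn(-c3cccc(C(=O)/C=C/c4ccc(O)c(OC)c4)c3)c(=O)[nH]2)cc1` is not yet measured. It differs from compound 1 by methoxy in place of chloro on an aromatic carbon. Among the compounds with values here, no measured step exchanges chloro for methoxy; the only step that touches this ring, a 1.7-fold higher number from compound 2 to compound 3 (0.24 log units; within the scatter), stayed within the scatter. The data therefore offer no ground for a change beyond the scatter in this assay. Compound 4 is expected to give about 2800 nM, in the range 1400 nM to 5600 nM, an expected step of a 1.1-fold higher number from compound 1 to compound 4 (0.03 log units; within the scatter).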

Compound 4, concentration for 50% growth inhibition: 4990 nM
For compound 4 the middle estimate is 1.8-fold (0.25 log units) below the measured one; the measured number falls inside the stated range.
By their numbers in this assay, from the lowest: compounds 2, 1, 3 and 4 (each within the scatter of the next, the first and the last beyond it).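

In this assay, 4-methoxyphenyl in place of 4-chlorophenyl gives a 1.9-fold higher number from compound 1 to compound 4 (0.28 log units; within the scatter), so this exchange, para to a large group, stays within the scatter. With the 4-methoxyphenyl group kept, 4-hydroxy-3-methoxyphenyl in place of 3,4,5-trimethoxyphenyl gives a 1.6-fold higher number from compound 3 to compound 4 (0.21 log units; within the scatter), which also stays within the scatter. Nothing at hand offers an account of these numbers. On these data alone, whether an amine or a carboxylic acid at this place would move the number beyond the scatter remains open. So does whether the exchange of chloro for methoxy reads the same with the 3,4,5-trimethoxyphenyl group present.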